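Bromine for chlorine on the benzyl ring: cytotoxicity outlook

This account rests on a few compounds, and the source may have more. Where it says the series, first, only, none or still open, it means among the compounds named here.

Compound 3 `COc1cc(-c2nnc(SCc3cccc(Cl)c3)o2)ccc1O` stands highest of the three numbers in an ADME assay on cells (Mus musculus, strain BALB/c) for cytotoxicity, read by MTT assay, with a stated time of 24 h (on this read-out lower numbers stand for higher toxicity in this test and higher numbers for lower toxicity in this test), where compound 3 gives 470000 nM. Its nearest neighbour is compound 2 `COc1cc(-c2nnc(SCc3cccc([N+](=O)[O-])c3)o2)ccc1O`, which in this assay gives 392000 nM, and its furthest is compound 1 `COc1cc(-c2nnc(SCc3ccccc3[N+](=O)[O-])o2)ccc1O`, which in this assay gives 331000 nM; both gaps to compound 3 lie within the scatter, so no order among the three can be read from them.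

Compound 4 `COc1cc(-c2nnc(SCc3ccc(Br)cc3)o2)ccc1O` differs from compound 3 in one place: 4-bromophenyl in place of 3-chlorophenyl on a saturated chain carbon bound to a sulfur. Going by the values given here, the only measured step that bears on a change of this kind is the one in which a halogen replaced a nitro group on the same ring, a 1.2-fold higher number from compound 2 to compound 3 (0.08 log units; within the scatter). Since that halogen-for-nitro exchange moved the number only within the scatter, an exchange of one halogen for another, at a different ring position, gives no ground to expect more.

Compound 4 is therefore expected to give about 450000 nM in this assay, with a likely range from 250000 nM to 800000 nM. For compound 4 the estimated step is a 1.0-fold lower number from compound 3 to compound 4 (0.02 log units; within the scatter), expected to stay within the scatter.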

Compound 4, half-maximal cytotoxic concentration: 455000 nM
For compound 4 the middle estimate is 1.0-fold (0.00 log units) below the measured one, and the stated range covers the measured number.
By their numbers in this assay, from the lowest: compounds 1, 2, 4 and 3 (each within the scatter of the next).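

In this assay the step is a 1.0-fold lower number from compound 3 to compound 4 (0.01 log units; within the scatter) for 4-bromophenyl in place of 3-chlorophenyl on a saturated chain carbon bound to a sulfur. The earlier step changed only the group on the ring, whereas this one changes the halogen and its ring position together, and the number still stays within the scatter, so this read-out does not tell these two phenyl groups apart. No evidence on the cause of this is at hand.

The compounds shown leave open whether the halogen and its ring position would each leave the number in place if changed alone, since here they change as one. They also leave open whether an amine or a carboxylic acid on this ring, or a longer chain at the sulfur, would stay within the scatter too.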